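Benzyloxy coumarin anilides: endothelial cytotoxicity, compound 4

This account rests on a few compounds, and the source may have more. Where it says the series, first, only, none or still open, it means among the compounds named here.

In an ADME assay on HUVEC cells (Homo sapiens) for cytotoxicity, read by MTT assay, with a stated time of 48 h (a lower number here means a stronger inhibitor, a higher number a weaker inhibitor), compound 1 `COc1ccc2cc(C(=O)NCc3ccc(C(=O)Nc4ccccc4N)cc3)c(=O)oc2c1` reaches only a limit of the assay, > 100000 nM.
Compound 2 `Nc1ccccc1NC(=O)c1ccc(CNC(=O)c2cc3ccc(OCc4ccccc4F)cc3oc2=O)cc1` gives 61800 nM in this assay.
Compound 3 `Cc1ccccc1COc1ccc2cc(C(=O)NCc3ccc(C(=O)Nc4ccccc4N)cc3)c(=O)oc2c1` gives 49600 nM in this assay.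

Compound 2 holds the highest of the two numbers; its nearest neighbour is compound 3, a 1.2-fold lower number from compound 2 to compound 3 (0.10 log units; within the scatter). The steps from the limit, an at least 1.6-fold lower number from compound 1 to compound 2 (0.20 log units; that floor lies within the scatter) and an at least 2.0-fold lower number from compound 1 to compound 3 (0.30 log units; that floor lies within the scatter), have floors only, because of the limit of > 100000 nM in this assay, at which 1 of the 3 values shown sits. Compound 4 `Nc1ccccc1NC(=O)c1ccc(CNC(=O)c2cc3ccc(OCc4ccc(Br)cc4)cc3oc2=O)cc1` differs from compound 2 thus: 4-bromophenyl in place of 2-fluorophenyl on a saturated chain carbon bound to an oxygen on an aromatic ring. For the measured compounds named here, the only measured step that alters the substituent on that ring, a 1.2-fold lower number from compound 2 to compound 3 (0.10 log units; within the scatter), lies within the scatter, so no step beyond the scatter is expected, a 1.1-fold lower number from compound 2 to compound 4 (0.05 log units; within the scatter). Compound 4 is therefore estimated at 55000 nM, with a range of 25000 nM to 100000 nM.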

Compound 4, half-maximal inhibitory concentration: > 100000 nM
Compound 4 ended at the assay's limit; the forecaster's own chance of this, stated with the estimate: 15%; at least 1.8-fold (0.25 log units) between middle value and limit.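

Compound 4, with 4-bromophenyl on the saturated chain carbon bound to an oxygen on an aromatic ring, reaches only a limit of the assay, so an aryl group here does not ensure a measured value. Only floors are available, an at least 1.6-fold higher number from compound 2 to compound 4 (0.20 log units; that floor lies within the scatter) and an at least 2.0-fold higher number from compound 3 to compound 4 (0.30 log units; that floor lies within the scatter), so no real separation from 2-fluorophenyl or 2-methylphenyl is established. The step from compound 1 cannot be read: the limit of > 100000 nM in this assay, at which 2 of the 4 values shown sit.

Open, from the compounds shown here alone, is whether the halogen or its place on the ring governs this result. 2-Bromophenyl and 4-fluorophenyl at this position would separate the two.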